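A few compounds are considered here, and "the series" means these few. Any claim that something is new, unique, unknown or untested is made for them only; others in the source may bear on it.

Of the compounds shown here, three built on the same core have been tested in a functional assay on KYSE-450 cells (Homo sapiens) for inhibition, read by MTT assay, with a stated time of 48 h; a higher number here means a weaker inhibitor, a lower number a stronger inhibitor. In this assay compound 1 `C=C(C)C(=O)N(Cc1ccc(OC)c(O)c1)c1cc(OC)c(OC)c(OC)c1` gives 200 nM, compound 2 `C/C=C/C=C/C(=O)N(Cc1ccc(OC)c(O)c1)c1cc(OC)c(OC)c(OC)c1` gives 180 nM, and compound 3 `COc1ccc(CN(C(=O)C(C)C)c2cc(OC)c(OC)c(OC)c2)cc1O` gives 390 nM, the highest of the three numbers. Within the data shown here, two measured steps bear on the group attached to the carbonyl carbon: a 2.0-fold higher number from compound 1 to compound 3 (0.29 log units; within the scatter) and a 2.2-fold higher number from compound 2 to compound 3 (0.34 log units; beyond the scatter). Both are modest, so exchanging that group has so far shifted the numbers only a little. Compound 4 `COc1ccc(CN(C(=O)C[Se]C#N)c2cc(OC)c(OC)c(OC)c2)cc1O` alters the same place: a group of 4 heavy atoms (2 carbon, 1 nitrogen, 1 selenium; no ring) in place of a group of 3 heavy atoms (3 carbon; no ring), on a carbonyl carbon. Among the measured compounds shown here, no measured step covers this new group, so only a small shift, in either direction, is expected. Compound 4 is therefore estimated at 300 nM, within 100 nM to 900 nM, meaning an expected step of a 1.3-fold lower number from compound 3 to compound 4 (0.11 log units; within the scatter).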

Compound 4, half-maximal inhibitory concentration: 280 nM
Compound 4: middle estimate off by 1.1-fold (0.03 log units), on the high side; low and high end bracket the measured number.
By their numbers in this assay, from the lowest: compounds 2, 1, 4 and 3 (each within the scatter of the next, the first and the last beyond it).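

With a group holding selenium and a nitrile on the carbonyl carbon, where the earlier groups held only carbon, the number in this assay stays within the scatter of all three earlier compounds (a 1.4-fold lower number from compound 3 to compound 4 (0.14 log units; within the scatter); a 1.6-fold higher number from compound 2 to compound 4 (0.19 log units; within the scatter); a 1.4-fold higher number from compound 1 to compound 4 (0.15 log units; within the scatter)). This position therefore tolerates a group containing selenium and a triple bond without a shift that can be told from the scatter. Nothing measured here gives a reason for this result. The compounds shown leave open what a cyanomethyl group, with the nitrile but no selenium, would give at this place, and whether the selenium or the nitrile matters. From the compounds shown here alone, a group containing a ring or an amine on the same carbonyl carbon also remains open.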